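From 3-chlorophenyl to 4-bromophenyl on a shared core

The source may hold more compounds than are shown below. What is called first, only, known or untested is meant among the compounds shown, and "the series" means these compounds.

In a functional assay on A549 cells (Homo sapiens) for antiproliferative activity, read by MTT assay, with a stated time of 48 h (on this read-out higher numbers stand for weaker inhibition and lower numbers for stronger inhibition), compound 2 `COc1ccc(/C=C/c2cc(OC)cc(OC)c2/C=C/C(=O)c2cccc(Cl)c2)cc1` gives 5.6 ug/mL, and compound 1 `COc1ccc(/C=C/c2cc(OC)cc(OC)c2/C=C/C(=O)c2cccc(Br)c2)cc1` gives 8.1 ug/mL. Among the compounds with values here, these two numbers lie within the scatter of each other, so compound 2 cannot yet be ranked against the only other measured compound.

The next compound, compound 3 `COc1ccc(/C=C/c2cc(OC)cc(OC)c2/C=C/C(=O)c2ccc(Br)cc2)cc1`, differs from compound 2 as follows: 4-bromophenyl in place of 3-chlorophenyl on a carbonyl carbon. In words, 4-bromophenyl stands in place of 3-chlorophenyl on a carbonyl carbon.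

Within the data shown here, one measured step bears on this: a 1.4-fold lower number from compound 1 to compound 2 (0.16 log units; within the scatter), in which chloro takes the place of bromo on an aromatic carbon. That step speaks only to the exchange of one halogen for the other, and it did not rise above the scatter. Among the measured compounds shown here, no measured compound carries a 4-bromophenyl group, so that part of the change remains untested, and the estimate must stay wide.

With so little evidence, no change beyond the scatter is expected in this assay, and the expected step is a 1.3-fold higher number from compound 2 to compound 3 (0.10 log units; within the scatter). For compound 3 the estimated value is 7 ug/mL, with an expected range from 3 ug/mL to 16 ug/mL.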

Compound 3, half-maximal inhibitory concentration: 8.3 ug/mL
The estimate for compound 3 lay 1.2-fold (0.07 log units) below the measured number; the range from low to high includes it.
By their numbers in this assay, from the lowest: compounds 2, 1 and 3 (each within the scatter of the next).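

In this assay, within the data shown here, the 4-bromophenyl group gives the first reading of a halogen at this other place on the phenyl ring attached to the carbonyl carbon, and setting it against 3-bromophenyl isolates that one difference: a 1.0-fold higher number from compound 1 to compound 3 (0.01 log units; within the scatter). Setting 4-bromophenyl against 3-chlorophenyl, where the halogen differs as well, gives a 1.5-fold higher number from compound 2 to compound 3 (0.17 log units; within the scatter), so the three halogenated phenyl groups tested so far cannot be ranked, and neither the choice of halogen nor its place on the ring has yet produced a difference that can be told from ordinary assay noise. Nothing measured here offers an explanation for these readings.

The compounds shown leave open whether this position responds at all to a group of a different kind on the phenyl ring, such as an amine or a carboxylic acid, or to a ring with no halogen. As far as these compounds go, whether 4-chlorophenyl would read alike also remains open, as would the question of whether a larger replacement for the whole phenyl group would give a step beyond the scatter.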